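Swapping the Aryl Group on a Triazole Without Measured Activity

The source may report more compounds than this note shows. Statements on the series, on what has been measured and on what is new or still open speak of the compounds shown alone.

Compound 1, `N#CC1=C(N)Oc2c(c3nc4ccccc4nc3c3ccccc23)C12C(=O)N(Cc1cnnn1-c1ccccc1Cl)c1ccccc12`. In a functional assay on MCF7 cells (Homo sapiens) for antiproliferative activity, read by MTT assay, with a stated time of 48 h (on this read-out lower numbers stand for stronger inhibition and higher numbers for weaker inhibition), compound 1 gives only a limit, > 50000 nM.
Compound 2, `Cc1ccc(Cl)cc1-n1nncc1CN1C(=O)C2(C(C#N)=C(N)Oc3c2c2nc4ccccc4nc2c2ccccc32)c2ccccc21`. In this assay compound 2 gives only a limit, > 50000 nM.
Compound 3, `N#CC1=C(N)Oc2c(N)cc3nc4ccccc4nc3c2C12C(=O)N(Cc1cnnn1-c1ccc([N+](=O)[O-])cc1)c1ccccc12`. In this assay compound 3 gives only a limit, > 50000 nM.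

All three measured compounds share one core and differ only in the aryl group carried by the aromatic nitrogen of the triazole ring. None of them gives a number; every value is a limit, as summarised by the limit of > 50000 nM in this assay, at which 3 of the 3 values shown sit. Among the compounds with values here, the one step between compounds that differ in a single place, a step that the two limits leave unreadable from compound 1 to compound 2, is therefore unreadable, and it says nothing about how large the effect of exchanging that aryl group might be.

Compound 3 thus stands at the limit, where the two other values also sit. Compound 4, `N#CC1=C(N)Oc2c(N)cc3nc4ccccc4nc3c2C12C(=O)N(Cc1cnnn1-c1c(Cl)cc(Cl)cc1Cl)c1ccccc12`, is the next compound to be measured in this assay. It differs from compound 3 in one place: 2,4,6-trichlorophenyl in place of 4-nitrophenyl on an aromatic nitrogen.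

Within the data shown here, no measured step bears on this change in a readable way, so no direction or size can be drawn from the data, and the step is expected to remain unreadable: a number no higher from compound 3 to compound 4 (the limit leaves the size open). Compound 4 is expected to give 50000 nM in this assay, within a range from 15000 nM to 200000 nM, most likely again only as a limit.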

Compound 4, half-maximal inhibitory concentration: 37800 nM
Estimate against measurement, compound 4: 1.3-fold (0.12 log units) above, within the range that was stated.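

Within the data shown here, compound 4 is the first compound to give a number rather than a limit: in this assay compound 4 gives 37800 nM. This shows that changing the aryl group on the aromatic nitrogen of the triazole can bring a reading within the measurable range, and exchanging 4-nitrophenyl for 2,4,6-trichlorophenyl gives an at least 1.3-fold lower number from compound 3 to compound 4 (0.12 log units; that floor lies within the scatter). That figure is only a floor for the step, and the steps between the other compounds still cannot be read, so the series offers no second number to compare with: the limit of > 50000 nM in this assay, at which 3 of the 4 values shown sit.

The single exchange removes the nitro group and brings in three chlorine atoms at once, so the compounds shown leave open whether the loss of the one or the arrival of the others accounts for the number, and how far the true step reaches past its floor. They also leave open what a plain phenyl, a 4-methoxyphenyl or a 4-aminophenyl group would give at this same place on the shared core.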